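A few compounds are considered here, and "the series" means these few. Any claim that something is new, unique, unknown or untested is made for them only; others in the source may bear on it.

Compound 2 `Cc1nc(N[C@@H]2C[C@H]3CC[C@@H]2C3)c2cc(-c3ccc(Cl)cc3)ccc2n1` and compound 1 `Cc1nc(N[C@@H]2C[C@H]3CC[C@@H]2C3)c2cc(-c3ccc(C(F)(F)F)cc3)ccc2n1` share one core and differ in a single place: trifluoromethyl in place of chloro on an aromatic carbon. In an ADME assay (Rattus norvegicus) for metabolic stability (on this read-out lower numbers stand for a less stable compound and higher numbers for a more stable compound), compound 2 gives 49%, while compound 1 gives 77%, so this change brought a number 28 percentage points higher from compound 2 to compound 1 (beyond the scatter). Compound 3 `Cc1nc(N[C@@H]2C[C@H]3CC[C@@H]2C3)c2cc(-c3cccc(Cl)c3)ccc2n1` differs from compound 2 by 3-chlorophenyl in place of 4-chlorophenyl on an aromatic carbon; in this assay compound 3 gives 23%, which is a number 26 percentage points lower from compound 2 to compound 3 (beyond the scatter). Compound 4 `Cc1nc(N[C@@H]2C[C@H]3CC[C@@H]2C3)c2cc(-c3cccc(C(F)(F)F)c3)ccc2n1` has not yet been measured; it differs from compound 3 by trifluoromethyl in place of chloro on an aromatic carbon. This is the same kind of change as that from compound 2 to compound 1, but there the entering group sits para to a large group, whereas in compound 4 it sits meta to a large group. Because the earlier change gave a number 28 percentage points higher from compound 2 to compound 1 (beyond the scatter), compound 4 is expected to show a number 25 percentage points higher from compound 3 to compound 4 (beyond the scatter) in this assay. Compound 4 is thus estimated at 48%, expected to fall between 30% and 68%.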

Compound 4, percent of the compound remaining: 41%
Compound 4: the middle estimate sits 7 percentage points above what was measured; the measured number falls inside the stated range.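

In this assay, trifluoromethyl in place of chloro gave a number 18 percentage points higher from compound 3 to compound 4 (beyond the scatter), so the change went the same way on the second core. The size of the step also cannot be told apart from the earlier one: the same change on two cores in this assay, a number 28 percentage points higher (beyond the scatter) from compound 2 to compound 1 and a number 18 percentage points higher (beyond the scatter) from compound 3 to compound 4, 10 percentage points apart, within the scatter of two such steps. Within the data shown here, this shows that the change carried over between these two cores, but it rests on only two pairs and does not show that it would carry over to any other core, or why the number goes up.

The compounds shown leave open how other groups in the same place, such as a nitrile or a methoxy group, would fare in this assay. They also leave open whether the step would hold if the methyl on the shared core gave way to an amine.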